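The source may report more compounds than this note shows. Statements on the series, on what has been measured and on what is new or still open speak of the compounds shown alone.

In a functional assay on MDA-MB-231 cells (Homo sapiens) for antiproliferative activity, read by MTT assay, with a stated time of 72 h (on this read-out higher numbers stand for weaker inhibition and lower numbers for stronger inhibition), three compounds with the same core have been measured: compound 1 `O=C(CCc1cccc2c1B(O)OC2)Nc1cccc(-c2cccc(Cl)c2)c1` gives 250 nM, compound 2 `O=C(CCc1cccc2c1B(O)OC2)Nc1cccc(-c2cccc(OC(F)(F)F)c2)c1` gives 460 nM and compound 3 `O=C(CCc1cccc2c1B(O)OC2)Nc1cccc(-c2cccc(C(F)(F)F)c2)c1` gives 410 nM. Compound 3 thus lies within the usual scatter of both others. Compound 4 `CC(=O)c1cccc(-c2cccc(NC(=O)CCc3cccc4c3B(O)OC4)c2)c1` carries acetyl in place of trifluoromethyl on an aromatic carbon. Going by the values given here, three measured steps bear on this swap: a 1.8-fold higher number from compound 1 to compound 2 (0.26 log units; within the scatter), a 1.6-fold higher number from compound 1 to compound 3 (0.21 log units; within the scatter) and a 1.1-fold lower number from compound 2 to compound 3 (0.05 log units; within the scatter). All stay within the scatter, but none involves acetyl, so the guidance is limited. No step beyond the scatter is expected, and the estimate is a 1.2-fold higher number from compound 3 to compound 4 (0.09 log units; within the scatter). For compound 4, the estimated value is 500 nM, with an expected range from 200 nM to 1200 nM.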

Compound 4, half-maximal inhibitory concentration: 52 nM
Compound 4: the middle estimate sits 9.6-fold (0.98 log units) above what was measured; measured number outside the range, below it.
By their numbers in this assay, from the lowest: compound 4; then compounds 1, 3 and 2 (each within the scatter of the next).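

Within this assay the swaps among chloro, trifluoromethyl and trifluoromethoxy at this position all stayed within the scatter, so the position seemed indifferent to the group it carried. Acetyl shows otherwise: it gives a 7.9-fold lower number from compound 3 to compound 4 (0.90 log units; beyond the scatter) and an 8.8-fold lower number from compound 2 to compound 4 (0.95 log units; beyond the scatter) and a 4.8-fold lower number from compound 1 to compound 4 (0.68 log units; beyond the scatter) and all three steps lie beyond the scatter. Nothing at hand explains why acetyl stands apart from the other three groups. It remains open whether any carbonyl group at this position would do the same, since acetyl alone among these groups carries one. A methyl ester, a primary amide or the longer propionyl group on the same carbon would help to settle that.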